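Replacing Isopropyl with Iodo in an Aryl Sulfonate Series

The source may hold more compounds than are shown below. What is called first, only, known or untested is meant among the compounds shown, and "the series" means these compounds.

Compound 1, `CC(C)C(=O)Nc1ccc(S(=O)(=O)Oc2ccccc2C(C)C)cc1`: 4900 nM
Compound 2, `CC(C)C(=O)Nc1ccc(S(=O)(=O)Oc2ccccc2I)cc1`: 3300 nM
Compound 3, `CC(C)c1ccccc1OS(=O)(=O)c1ccc(NC(=O)NCC2CCCC2)cc1`: 6000 nM

All three compounds were tested in a functional assay on HT-1080 cells (Homo sapiens) for antiproliferative activity, read by sulforhodamine B assay, with a stated time of 48 h (a lower number here means a stronger inhibitor, a higher number a weaker inhibitor), which reports how much of a compound is needed to hold back the growth of a tumour cell line. In this assay compound 1 gives 4900 nM, compound 2 gives 3300 nM and compound 3 gives 6000 nM.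

Compound 1 and compound 2 differ by one change, (iodo in place of isopropyl on an aromatic carbon). This gave a 1.5-fold lower number from compound 1 to compound 2 (0.17 log units; within the scatter), so the two numbers cannot be told apart with confidence. Compound 1 and compound 3 share the same aryl sulfonate but differ in the group on the carbonyl, ((cyclopentylmethyl)amino in place of isopropyl on a carbonyl carbon); this too gave a 1.2-fold higher number from compound 1 to compound 3 (0.09 log units; within the scatter).

Compound 4, `O=C(NCC1CCCC1)Nc1ccc(S(=O)(=O)Oc2ccccc2I)cc1`, has not yet been measured. It stands to compound 3 as compound 2 stands to compound 1: the difference is iodo in place of isopropyl on an aromatic carbon, at a place described in the same words for both pairs, so it is the same change. Among the compounds with values here, with only one earlier example to go on, the expectation rests on compound 1 and compound 2, whose pair gave a 1.5-fold lower number from compound 1 to compound 2 (0.17 log units; within the scatter), and the step from compound 3 to compound 4 is expected to be of similar size, a 1.5-fold lower number from compound 3 to compound 4 (0.18 log units; within the scatter). Compound 4 is therefore estimated at 4000 nM, with a plausible range from 2000 nM to 8000 nM.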

Compound 4, half-maximal inhibitory concentration: 6100 nM
Compound 4: middle estimate off by 1.5-fold (0.18 log units), on the low side; measured number inside the range.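

In this assay, iodo in place of isopropyl on an aromatic carbon gave a 1.0-fold higher number from compound 3 to compound 4 (0.01 log units; within the scatter), and the two cores show no measurable difference in how this change behaves: the same change on two cores in this assay, a 1.5-fold lower number (0.17 log units; within the scatter) from compound 1 to compound 2 and a 1.0-fold higher number (0.01 log units; within the scatter) from compound 3 to compound 4, 1.5-fold (0.18 log units) apart, within the scatter of two such steps. The other change, (cyclopentylmethyl)amino in place of isopropyl on a carbonyl carbon, gave a 1.8-fold higher number from compound 2 to compound 4 (0.27 log units; within the scatter) with iodo present, and it too reads alike in both pairs: the same change on two cores in this assay, a 1.2-fold higher number (0.09 log units; within the scatter) from compound 1 to compound 3 and a 1.8-fold higher number (0.27 log units; within the scatter) from compound 2 to compound 4, 1.5-fold (0.18 log units) apart, within the scatter of two such steps. This shows that neither change moved the number beyond the scatter on either core, but with no clear effect to carry across, it does not show that a real effect would transfer from one core to another, and two pairs per change are too few to support a general rule.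

The compounds shown leave open whether another group in place of iodo or isopropyl on that aromatic carbon, such as methoxy, a nitrile or a carboxylic acid, would produce a step beyond the scatter. They also leave open whether a different group on the carbonyl carbon, such as a longer chain or a chain ending in an amine, would do so, and whether any such step would then hold on both cores.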